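A few compounds are considered here, and "the series" means these few. Any claim that something is new, unique, unknown or untested is made for them only; others in the source may bear on it.

Measured compounds:
compound 1 `Cc1c(Cl)ccc(S(=O)(=O)N(C)CCOCC(=O)N(C)Cc2ccc(C3=NCCN3)cc2)c1Cl`: 7.5
compound 2 `COc1cc(C)c(S(=O)(=O)N(C)CCOCC(=O)N(C)Cc2ccc(C3=NCCN3)cc2)c(C)c1`: 8.2
compound 3 `CN(Cc1ccc(C2=NCCN2)cc1)C(=O)COCCN(C)S(=O)(=O)c1c(F)cccc1F`: 6

In a functional assay for antagonist activity at B1 bradykinin receptor (Mus musculus), using Schild analysis, with a stated time of 30 min (on this read-out lower numbers stand for lower potency and higher numbers for higher potency (the scale is a negative logarithm)), compound 1 stands second of the three, with compound 2 the nearest by a number 0.70 log units higher from compound 1 to compound 2 (beyond the scatter) and compound 3 the furthest by a number 1.50 log units lower from compound 1 to compound 3 (beyond the scatter). Compound 4 `CN(Cc1ccc(C2=NCCN2)cc1)C(=O)COCCN(C)S(=O)(=O)c1c(Cl)cccc1Cl` has not been measured; it differs from compound 1 in that (2,6-dichlorophenyl in place of 2,4-dichloro-3-methylphenyl on a sulfonyl sulfur). Of the measured steps, the one that bears on this change is a number 1.50 log units lower from compound 1 to compound 3 (beyond the scatter), which also exchanges the group on the sulfonyl sulfur for one carrying two halogens and nothing else on the ring; the step of a number 2.20 log units lower from compound 2 to compound 3 (beyond the scatter) points the same way. A step down beyond the scatter is therefore expected for compound 4, though not necessarily as large as that to compound 3. The estimate for compound 4 in this assay is 6.8 (range 6 to 7.6), meaning an expected step of a number 0.70 log units lower from compound 1 to compound 4 (beyond the scatter).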

Compound 4, negative logarithm of the antagonist equilibrium constant: 7.2
The estimate for compound 4 lay 0.40 log units below the measured number; the range from low to high includes it.
By their numbers in this assay, from the lowest: compound 3; then compounds 4 and 1 (each within the scatter of the next); then compound 2.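

In this assay, a sulfonyl sulfur carrying a ring with two halogens and nothing else need not lose potency against compound 1 (a number 0.30 log units lower from compound 1 to compound 4 (within the scatter)). Chlorine in place of fluorine on that ring recovers much of the loss (a number 1.20 log units higher from compound 3 to compound 4 (beyond the scatter)), so the low value of compound 3 belongs to 2,6-difluorophenyl, not to every dihalophenyl. Compound 2 stays clearly ahead (a number 1.00 log units lower from compound 2 to compound 4 (beyond the scatter)).

No measurement here accounts for the gap between the two halogens. On these data alone, whether 2,6-dibromophenyl or 2,6-dimethylphenyl would match compound 4 or compound 2 remains open.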